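This account rests on a few compounds, and the source may have more. Where it says the series, first, only, none or still open, it means among the compounds named here.

Compound 1 `CC(C)c1onc(-c2c(Cl)cccc2Cl)c1COc1ccc(-c2nc3ccc(C(=O)O)cc3n2Cc2ccc(F)cc2)cc1` — 105 nM
Compound 2 `CC(C)c1onc(-c2c(Cl)cccc2Cl)c1COc1ccc(-c2nc3ccc(C(=O)O)cc3n2C2CC2)cc1` — 117 nM

In an assay on isolated protein for agonist activity at Bile acid receptor (Homo sapiens), read by TR-FRET (on this read-out lower numbers stand for an effect already at smaller amounts and higher numbers for an effect only at larger amounts of compound), compound 2 gives 117 nM. Among the compounds with values here, its only measured companion is compound 1, which in this assay gives 105 nM; the step of a 1.1-fold higher number from compound 1 to compound 2 (0.05 log units; within the scatter) is within the scatter, so the two compounds stand together on the numbers at hand.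

Compound 3 `CC(C)c1onc(-c2c(Cl)cccc2Cl)c1COc1ccc(-c2nc3ccc(C(=O)O)cc3n2-c2ccc(F)cc2)cc1` has not yet been measured. It differs from compound 2 by 4-fluorophenyl in place of cyclopropyl on an aromatic nitrogen. Within the data shown here, the one measured step that bears on this position is a 1.1-fold higher number from compound 1 to compound 2 (0.05 log units; within the scatter), where a 4-fluorobenzyl gave way to a cyclopropyl at the same aromatic nitrogen without moving the number beyond the scatter. The 4-fluorophenyl that enters in compound 3 is the closest relative of that 4-fluorobenzyl among the groups seen here. Because a 1.1-fold higher number from compound 1 to compound 2 (0.05 log units; within the scatter) stayed within the scatter, no step beyond the scatter is expected in this assay, and the estimated step is a 1.1-fold lower number from compound 2 to compound 3 (0.03 log units; within the scatter). Compound 3 is therefore expected to give about 110 nM, in a range from 50 nM to 250 nM.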

Compound 3, half-maximal effective concentration: 15.1 nM
For compound 3 the middle estimate is 7.3-fold (0.86 log units) above the measured one, outside the stated range (below it).
By their numbers in this assay, from the lowest: compound 3; then compounds 1 and 2 (each within the scatter of the next).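

In this assay the aromatic nitrogen proves sensitive to what it carries: 4-fluorophenyl in place of cyclopropyl gives a 7.7-fold lower number from compound 2 to compound 3 (0.89 log units; beyond the scatter) and 4-fluorophenyl in place of 4-fluorobenzyl gives a 7.0-fold lower number from compound 1 to compound 3 (0.84 log units; beyond the scatter) in the same direction. The earlier pair showed only that cyclopropyl and 4-fluorobenzyl stand together, which said nothing about an aromatic ring joined straight to this nitrogen. As 4-fluorobenzyl and 4-fluorophenyl share the fluorinated ring, the second step shows that how this ring is joined to the nitrogen counts here, though nothing at hand explains why.

As far as these compounds go, it remains open whether the fluorine plays any part in these steps, which a plain phenyl would test. Also open, from the compounds shown here alone, is whether a pyridyl or 4-chlorophenyl group on the same nitrogen would give a similar number.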